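A Methoxy Swap at a Tolerant Aromatic Position

The compounds below may be only part of what the source reports. "The series", "measured", "known", "first", "only" and "open" are said of these compounds alone.

Three compounds share one core. Compound 1 `NC(=O)c1c(NC(=O)c2ccccc2)sc2c1CCN(C(=S)Nc1ccccc1Cl)C2` gives 13800 nM in a functional assay on HL-60 cells (Homo sapiens) for antiproliferative activity, with a stated time of 24 h; on this read-out higher numbers stand for weaker inhibition and lower numbers for stronger inhibition. Compound 2 `NC(=O)c1c(NC(=O)c2ccccc2F)sc2c1CCN(C(=S)Nc1ccccc1Cl)C2` gives 12500 nM, and compound 3 `NC(=O)c1c(NC(=O)c2ccccc2C(F)(F)F)sc2c1CCN(C(=S)Nc1ccccc1Cl)C2` gives 17600 nM. Compound 3 holds the highest of the three numbers, yet the steps of a 1.3-fold higher number from compound 1 to compound 3 (0.11 log units; within the scatter) and a 1.4-fold higher number from compound 2 to compound 3 (0.15 log units; within the scatter) both fall inside the scatter, as does a 1.1-fold lower number from compound 1 to compound 2 (0.04 log units; within the scatter). Compound 4 `COc1ccccc1C(=O)Nc1sc2c(c1C(N)=O)CCN(C(=S)Nc1ccccc1Cl)C2` differs from compound 3 by methoxy in place of trifluoromethyl on an aromatic carbon. The three measured steps all changed a group on that same aromatic carbon, and none moved the number beyond the scatter. Since every measured step stayed inside the scatter, the expected step for compound 4 is a 1.3-fold lower number from compound 3 to compound 4 (0.10 log units; within the scatter), again within the scatter. Compound 4 is therefore estimated at 14000 nM, within 7000 nM to 28000 nM.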

Compound 4, half-maximal inhibitory concentration: 20800 nM
Compound 4: the middle estimate sits 1.5-fold (0.17 log units) below what was measured; the range from low to high includes it.
By their numbers in this assay, from the lowest: compounds 2, 1, 3 and 4 (each within the scatter of the next).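

Methoxy adds a hydrogen-bond acceptor that trifluoromethyl lacks, yet in this assay the number stays within the scatter against each earlier group (a 1.2-fold higher number from compound 3 to compound 4 (0.07 log units; within the scatter); a 1.7-fold higher number from compound 2 to compound 4 (0.22 log units; within the scatter); a 1.5-fold higher number from compound 1 to compound 4 (0.18 log units; within the scatter)). Hydrogen, fluoro, trifluoromethyl and methoxy on this aromatic carbon therefore give numbers that these steps cannot separate. No evidence is available on what lies behind this flat result. Still open, from the compounds shown here alone, is whether an amine or a carboxylic acid on this carbon would move the number beyond the scatter.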